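Tolerance of a fluorophenyl series on Vero cells

A few compounds are considered here, and "the series" means these few. Any claim that something is new, unique, unknown or untested is made for them only; others in the source may bear on it.

Measured so far:
compound 1 `CC(=O)c1c(Nc2ccc(F)cc2F)[nH]c2c(F)cc(F)cc2c1=O` – > 25000 nM
compound 2 `CC(=O)c1c(Nc2ccc(F)c(F)c2F)[nH]c2c(F)cc(F)cc2c1=O` – > 25000 nM
compound 3 `CC(C)C(=O)c1c(Nc2ccc(F)c(F)c2F)[nH]c2c(Cl)cc(Cl)c(Cl)c2c1=O` – 6400 nM

In an ADME assay on Vero cells (Chlorocebus sabaeus) for cytotoxicity (a lower number here means that less compound is tolerated, a higher number that more compound is tolerated), compound 1 reaches only a limit of the assay, > 25000 nM. In this assay compound 2 likewise reaches only a limit, > 25000 nM. In this assay, among the measured compounds shown here, compound 3 gives the single proper number of the set, 6400 nM. The difference between the core of compound 2 and the core of compound 3 is not broken down here.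

Compound 1 and compound 2 differ by hydrogen in place of fluoro on an aromatic carbon. The step that the two limits leave unreadable from compound 2 to compound 1 stays unreadable because both of its ends sit at the limit of > 25000 nM in this assay, at which 2 of the 3 values shown sit.

The unmeasured compound 4 `CC(C)C(=O)c1c(Nc2ccc(F)cc2F)[nH]c2c(Cl)cc(Cl)c(Cl)c2c1=O` carries the same change on the core of compound 3: hydrogen in place of fluoro on an aromatic carbon. Since the earlier instance of this change left no readable step, the expectation for compound 4 rests mainly on the value of compound 3, 6400 nM, and on the change being a single fluoro removed on the aryl ring. Compound 4 is therefore expected to sit close to compound 3, with an estimated step of a 1.1-fold higher number from compound 3 to compound 4 (0.04 log units; within the scatter). Compound 4 is estimated at 7000 nM, with a likely range from 3000 nM to 20000 nM.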

Compound 4, half-maximal cytotoxic concentration: > 25000 nM
Compound 4 ended at the assay's limit; the forecaster's own chance of this, stated with the estimate: 15%; at least 3.5-fold (0.55 log units) between middle value and limit.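

In this assay, replacing fluoro by hydrogen on an aromatic carbon, which turns 2,3,4-trifluorophenyl into 2,4-difluorophenyl, gives an at least 3.9-fold higher number from compound 3 to compound 4 (0.59 log units; beyond the scatter). Compound 4 reaches only a limit of the assay, > 25000 nM, so this step gives a minimum size and not a full one. The same change cannot be read on the core of compound 2, so the step is seen on one core only and the data do not show whether it carries from one core to another: the limit of > 25000 nM in this assay, at which 3 of the 4 values shown sit.

The compounds shown leave open what other groups at the same aromatic carbon would do in this assay, for example chloro, methoxy or a nitrile in place of the fluoro. They also leave open how the separate differences between the core of compound 2 and the core of compound 3 each bear on the read-out, including what a single chloro or a longer chain on the ketone would do on its own.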